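Dropping the Methoxy Group: Expectation for Compound 3

The source may hold more compounds than are shown below. What is called first, only, known or untested is meant among the compounds shown, and "the series" means these compounds.

Measured compounds:
Compound 1, `C=CCn1c(SC/C(=N\O)c2ccccc2)nnc1-c1ccc(OC)c(OC)c1`, gives 53%.
Compound 2, `COc1ccc(-c2nnc(SC/C(=N/O)c3ccccc3)n2-c2ccccc2)cc1`, gives 58%.

Both were tested in a functional assay on the whole organism (strain albino) for inhibition, with Rattus norvegicus as the target, read by paw edema, with a stated time of 1 h, at a dose of 0.28 mmol/kg by the oral route; on this read-out lower numbers stand for less inhibition and higher numbers for more inhibition at the one dose given (going by the name of the read-out). Compound 2 serves as the reference point here, yet its value and that of compound 1 lie within the usual scatter of each other, so on these two numbers the compounds are effectively alike, and nothing can be read into which of them is written first.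

Compound 3, `O/N=C(/CSc1nnc(-c2ccccc2)n1-c1ccccc1)c1ccccc1`, has not yet been measured in this assay. It differs from compound 2 in one place only: hydrogen in place of methoxy on an aromatic carbon Seen one bond further out, the same difference reads 4-methoxyphenyl to phenyl.

Among the measured compounds shown here, no pair of measured compounds shows what this change does to the read-out, so the expectation rests on the structural change alone and is no more than a guess of a small loss. The step expected from the change is a number 8 percentage points lower from compound 2 to compound 3 (within the scatter), small enough that it may well fall inside the scatter. In this assay compound 3 is estimated at 50%, with a range from 35% to 65%.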

Compound 3, a percentage reported as inhibition, in the whole organism at one dose (the size of the read-out at that dose, not a potency): 60%
Beside the measured number, compound 3's estimate is 10 percentage points below it, and the stated range covers the measured number.
By their numbers in this assay, from the lowest: compounds 1, 2 and 3 (each within the scatter of the next).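

In this assay, putting hydrogen in place of methoxy on an aromatic carbon para to a large group gives a number 2 percentage points higher from compound 2 to compound 3 (within the scatter), so compound 2 and compound 3 are effectively alike on this read-out. Among the compounds shown here, this is the first direct reading of the change, and it shows that, in this pair, 4-methoxyphenyl can give way to phenyl with no difference that this single-dose measurement can separate from ordinary scatter. No accompanying data offer an explanation for this result.

The compounds shown leave open whether a different group at this position, such as a hydroxyl group, an amine, a chlorine atom or a carboxylic acid, would move the read-out beyond the scatter, since hydrogen and methoxy are the only two groups compared here. As far as these compounds go, it is also open whether the same exchange would give a similar result on the core of compound 1, and whether the likeness of compound 2 and compound 3 would hold at other doses or at other times after dosing.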